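The source may hold more compounds than are shown below. What is called first, only, known or untested is meant among the compounds shown, and "the series" means these compounds.

Compound 1, `Cc1noc(-c2nc(C)c3c(c2N)C(=O)N(Cc2ccc(F)cc2)C3=O)n1`: in a physicochemical assay for solubility, using the shake flask method, in simulated intestinal fluid, measured as kinetic solubility, with a stated time of 2 h, at 25 degrees C, at pH 6.5 (on this read-out lower numbers stand for lower solubility and higher numbers for higher solubility), compound 1 gives < 5000 nM, which is a limit of the assay and not a number.
Compound 2, `Cc1noc(-c2nc(C)c3c(c2N)C(=O)N(Cc2ccc(Oc4ccc(F)cc4)cc2)C3=O)n1`: in this assay compound 2 gives 23800 nM.
Compound 3, `Cc1noc(-c2nc(C)c3c(c2N)C(=O)N(Cc2ccc(Br)cc2)C3=O)n1`: in this assay compound 3 gives < 5000 nM, again a limit of the assay.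

Compound 3 therefore stands at the limit of < 5000 nM in this assay, at which 2 of the 3 values shown sit, and only compound 2 carries a measured number. For the measured compounds named here, the one readable step involving compound 3 is an at least 4.7-fold lower number from compound 2 to compound 3 (0.67 log units; beyond the scatter); the other, a step that the two limits leave unreadable from compound 1 to compound 3, cannot be sized. The change now followed leads to compound 4, `Cc1noc(-c2nc(C)c3c(c2N)C(=O)N(Cc2ccc(C(N)=O)cc2)C3=O)n1`, and reads: carbamoyl in place of bromo on an aromatic carbon. Going by the values given here, none of the measured steps exchanges bromo for carbamoyl, so none bears on it directly; the only step that leaves bromo, an at least 4.7-fold lower number from compound 2 to compound 3 (0.67 log units; beyond the scatter) read in reverse, concerns 4-fluorophenoxy instead. With compound 3 at a limit, any step that the assay can read must point toward higher solubility, while a step that stays within the scatter or points lower would leave compound 4 at the same limit. Compound 4 is estimated at 15000 nM, with a range from 3000 nM to 60000 nM. That estimate for compound 4 means a step of an at least 3.0-fold higher number from compound 3 to compound 4 (0.47 log units; beyond the scatter), expected rather than known.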

Compound 4, solubility: < 5000 nM
Compound 4 gave a limit, no number; the forecaster's own chance of this, stated with the estimate: 35%; middle value at least 3.0-fold (0.47 log units) away from the limit.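

Compound 4 gives a limit in this assay, not a number, and it is the third compound at that same limit: the limit of < 5000 nM in this assay, at which 3 of the 4 values shown sit.

At this position, para to a large group, carbamoyl brings a hydrogen-bond donor and a hydrogen-bond acceptor that bromo lacks, yet compound 4 does not clear the limit, so 4-fluorophenoxy remains the only group shown that does. For the compounds shown here, exchanging that group for carbamoyl gives an at least 4.7-fold lower number from compound 2 to compound 4 (0.67 log units; beyond the scatter), the same kind of separation that the earlier compounds showed for bromo and fluoro. The steps that link compound 4 to compound 1 and compound 3 cannot be read, so carbamoyl cannot be ranked against either bromo or fluoro.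

From the compounds shown here alone, how compound 1, compound 3 and compound 4 stand relative to one another under the limit remains open, and a single compound with a measured number cannot show which part of 4-fluorophenoxy matters. Also open, going by these compounds, is how an unsubstituted phenoxy group, an amine or a carboxylic acid at this position would read in this assay.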